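This account rests on a few compounds, and the source may have more. Where it says the series, first, only, none or still open, it means among the compounds named here.

Measured compounds in a functional assay on U2OS cells with metabotropic glutamate receptor 5 (Homo sapiens) as the target, read by calcium flux; on this read-out higher numbers stand for larger maximal responses and lower numbers for smaller maximal responses:
- compound 1 `Fc1ccc(-c2noc(C3CCc4c(nnn4-c4ccc(F)cc4)C3)n2)cc1`: 106%
- compound 2 `CC(C)(C)Cn1nnc2c1CCC(c1nc(-c3ccc(F)cc3)no1)C2`: 108%
- compound 3 `CC(C)Cc1noc(C2CCc3c(nnn3C(C)(C)C)C2)n1`: 66%

Compound 3 stands lowest of the three in this assay; its gaps to compound 1 and to compound 2 both lie beyond the scatter, while compound 1 and compound 2 lie within the scatter of each other.

Compound 4 `CC(C)(C)n1nnc2c1CCC(c1nc(Cc3ccc(F)cc3)no1)C2` differs from compound 3 by 4-fluorophenyl in place of isopropyl on a saturated chain carbon bound to an aromatic carbon. Going by the values given here, the one measured step, a number 2 percentage points higher from compound 1 to compound 2 (within the scatter), exchanges groups on an aromatic nitrogen and lies within the scatter; it says nothing about a change on a saturated chain carbon. Among the compounds with values here, what remains is that compound 1 and compound 2, which carry 4-fluorophenyl, give the higher numbers, and compound 3, which carries isobutyl, gives the lower one; no measured pair differs in the place changed here. The expectation is therefore a rise, a number 24 percentage points higher from compound 3 to compound 4 (beyond the scatter), toward the values of compound 1 and compound 2, with wide uncertainty. Compound 4 is expected to give 90% in this assay, estimated between 65% and 112%.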

Compound 4, largest response reached (reported as percent of maximum), in percent of the reference or control that the assay uses: 77%
Estimate against measurement, compound 4: 13 percentage points above; measured number inside the range.
By their numbers in this assay, from the lowest: compound 3; then compound 4; then compounds 1 and 2 (each within the scatter of the next).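

In this assay the exchange of isobutyl for 4-fluorobenzyl gives a number 11 percentage points higher from compound 3 to compound 4 (beyond the scatter) and so moves the maximal response beyond the scatter. Going by these compounds alone, the only earlier step, an exchange on an aromatic nitrogen, stayed within the scatter with a number 2 percentage points higher from compound 1 to compound 2 (within the scatter) and therefore marks the saturated chain carbon as the first place where a single change registers. The rise is modest and rests on one pair, and nothing available here accounts for it.

Still open, on these data alone, is whether the aromatic ring or the fluorine carries the step, which plain benzyl and cyclohexylmethyl at this place would help to separate. Also open, as far as these compounds go, is how this place responds to a primary amine or a carboxylic acid, and whether the same exchange gives a similar step with neopentyl on the aromatic nitrogen.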